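The compounds below may be only part of what the source reports. "The series", "measured", "known", "first", "only" and "open" are said of these compounds alone.

Of the compounds shown here, two sharing one core have been measured. Compound 1 `Oc1ccc(-c2cc(-c3ccccc3F)cc(-c3ccc(O)cc3)n2)cc1` gives 8180 nM in a functional assay on HCT-15 cells (Homo sapiens) for inhibition; a lower number here means a stronger inhibitor, a higher number a weaker inhibitor. Compound 2 `Oc1ccc(-c2cc(-c3ccc(C(F)(F)F)cc3)cc(-c3cccc(O)c3)n2)cc1` gives 6440 nM in this assay, the lower of the two numbers, yet its gap to compound 1 lies within the scatter, so the two cannot be ranked. Compound 3 `Oc1ccc(-c2cc(-c3ccc(C(F)(F)F)cc3)cc(-c3ccc(O)cc3)n2)cc1` has not yet been measured; it differs from compound 2 by 4-hydroxyphenyl in place of 3-hydroxyphenyl on an aromatic carbon. Within the data shown here, no measured pair here shows the effect of that change, so no step beyond the scatter is expected in either direction. Compound 3 is therefore estimated to give about 7000 nM in this assay, expected between 3000 nM and 16000 nM. The expected step is a 1.1-fold higher number from compound 2 to compound 3 (0.04 log units; within the scatter).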

Compound 3, half-maximal inhibitory concentration: > 50000 nM
Compound 3: a limit, no number (the forecaster's own chance of this, stated with the estimate: 5%); middle value at least 7.1-fold (0.85 log units) away from the limit.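

Moving the hydroxyl alone, with the same atoms joined differently, matters at this position: in this assay, 4-hydroxyphenyl in place of 3-hydroxyphenyl next to the ring nitrogen gives an at least 7.7-fold higher number from compound 2 to compound 3 (0.89 log units; beyond the scatter). With both 4-hydroxyphenyl groups present, 4-(trifluoromethyl)phenyl in place of 2-fluorophenyl gives an at least 6.1-fold higher number from compound 1 to compound 3 (0.78 log units; beyond the scatter). Compound 3 stands at a limit of the assay, not at a number: the limit of > 50000 nM in this assay, at which 1 of the 3 values shown sits.

On these data alone, how far compound 3 lies beyond that limit stays open. So does whether an amine or a carboxylic acid in place of the hydroxyl would keep the number close to that of compound 2.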